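The source may report more compounds than this note shows. Statements on the series, on what has been measured and on what is new or still open speak of the compounds shown alone.

Measured so far:
- compound 1, `O=C(Nc1ccc(-n2ccc3nc(C(=O)NCc4ccccc4)ccc32)cc1)Nc1cccc(C(F)(F)F)c1`; in an ADME assay on HS27 cells (Homo sapiens) for cytotoxicity, read by MTT assay (on this read-out lower numbers stand for stronger inhibition and higher numbers for weaker inhibition), compound 1 gives > 10000 nM, which is a limit of the assay and not a number.
- compound 2, `COC(=O)c1ccc2c(ccn2-c2ccc(NC(=O)Nc3ccc(Cl)c(Cl)c3)cc2)n1`; compound 2 gives 2800 nM.
- compound 3, `NC(=O)c1ccc2c(ccn2-c2ccc(NC(=O)Nc3ccc(Cl)c(Cl)c3)cc2)n1`; compound 3 gives 6600 nM.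

Compound 2 has the lowest of the two numbers; its nearest neighbour is compound 3, reached by a 2.4-fold higher number from compound 2 to compound 3 (0.37 log units; beyond the scatter). Compound 4, `COC(=O)c1ccc2c(ccn2-c2ccc(NC(=O)Nc3cccc(Cl)c3Cl)cc2)n1`, differs from compound 2 by 2,3-dichlorophenyl in place of 3,4-dichlorophenyl on an amide-type nitrogen. For the measured compounds named here, the one measured step, a 2.4-fold higher number from compound 2 to compound 3 (0.37 log units; beyond the scatter), is an exchange on a carbonyl carbon and does not touch the dichlorophenyl, so no measured step bears on this change. With nothing to go by, a step within the usual scatter is expected: a 1.1-fold higher number from compound 2 to compound 4 (0.03 log units; within the scatter). Compound 4 is therefore estimated at 3000 nM, with a range from 1200 nM to 9000 nM.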

Compound 4, half-maximal inhibitory concentration: > 10000 nM
Compound 4: only a limit was reported; the forecaster's own chance of this, stated with the estimate: 20%; at least 3.3-fold (0.52 log units) between middle value and limit.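

In this assay, the exchange of 3,4-dichlorophenyl for 2,3-dichlorophenyl on an amide-type nitrogen gives an at least 3.5-fold higher number from compound 2 to compound 4 (0.55 log units; beyond the scatter), so the same atoms, joined differently, move the number at this place. Compound 2 and compound 3 share 3,4-dichlorophenyl and could not show this. The full size of the step stays unread because compound 4 gives a limit of the assay and not a number: the limit of > 10000 nM in this assay, at which 2 of the 4 values shown sit.

Going by these compounds, it remains open how a plain phenyl, or a phenyl with a single chlorine, would compare on that nitrogen. Also open, on these data alone, is whether amino in place of methoxy on the carbonyl carbon would act alike with 2,3-dichlorophenyl.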